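The source may hold more compounds than are shown below. What is called first, only, known or untested is meant among the compounds shown, and "the series" means these compounds.

Three compounds share one core and differ only in what sits on the six-membered aromatic ring of carbon only. Compound 1 `C=C1C(=O)OC[C@H]1CCOC(=O)Nc1cccc(Br)c1` carries bromo, compound 2 `C=C1C(=O)OC[C@H]1CCOC(=O)Nc1ccccc1F` carries fluoro, and compound 3 `C=C1C(=O)OC[C@H]1CCOC(=O)Nc1ccccc1` carries hydrogen there. In a functional assay on RAW264.7 cells (Mus musculus) for inhibition, with a stated time of 30 min (on this read-out higher numbers stand for weaker inhibition and lower numbers for stronger inhibition), compound 1 gives 590 nM, compound 2 gives 350 nM, and compound 3 gives 390 nM. Compound 3 thus stands within the scatter of both companions: the step of a 1.5-fold lower number from compound 1 to compound 3 (0.18 log units; within the scatter) and the step of a 1.1-fold higher number from compound 2 to compound 3 (0.05 log units; within the scatter) are each too small to count as a difference beyond the scatter.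

Compound 4 `C=C1C(=O)OC[C@H]1CCOC(=O)Nc1ccc(CC)cc1` differs from compound 3 by ethyl in place of hydrogen on an aromatic carbon, the ethyl sitting para to a large group. Going by the values given here, no measured step adds an ethyl, so only the two steps just described bear on it, and both show that swapping the group on this ring barely moves this assay. The same is expected here: for compound 4 the step of a 1.1-fold higher number from compound 3 to compound 4 (0.03 log units; within the scatter) is expected to stay within the scatter. Compound 4 is accordingly estimated at 420 nM, with a range from 200 nM to 900 nM.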

Compound 4, half-maximal inhibitory concentration: 840 nM
For compound 4 the middle estimate is 2.0-fold (0.30 log units) below the measured one; measured number inside the range.
By their numbers in this assay, from the lowest: compounds 2, 3, 1 and 4 (each within the scatter of the next, the first and the last beyond it).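

In this assay, going by these compounds alone, putting ethyl in place of hydrogen gives a 2.2-fold higher number from compound 3 to compound 4 (0.33 log units; beyond the scatter), so the change is modest but, unlike the earlier steps on this ring, lies beyond the scatter. The ring therefore does not tolerate every change equally: with ethyl para to a large group, inhibition is weaker than with hydrogen, whereas the bromo and fluoro steps could not be told apart from the scatter. Nothing available explains this loss of inhibition.

Hydrogen and ethyl are the only two groups compared directly at this position, so it remains open whether the loss belongs to ethyl alone or would appear with other groups there. A methyl, a longer chain such as propyl, or an amine at this carbon would help separate the effect of chain length from that of the kind of group.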